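This account rests on a few compounds, and the source may have more. Where it says the series, first, only, none or still open, it means among the compounds named here.

Working notes on the series

Three measured compounds share one core and differ only at the saturated chain carbon bound to an aromatic carbon: compound 1 `CCCc1c(C(N)C(=O)O)cnn1O`, compound 2 `NC(C(=O)O)c1cnn(O)c1CC1CC1` and compound 3 `NC(C(=O)O)c1cnn(O)c1Cc1ccccc1`. In a functional assay on CHO cells for agonist activity at metabotropic glutamate receptor 1 (Rattus norvegicus), read by calcium flux (a higher number here means that more compound is needed for the effect, a lower number that less compound is needed), compound 1 reaches only a limit of the assay, > 1000000 nM. Compound 2 likewise gives only a limit in this assay, > 1000000 nM. Compound 3 stands at a limit as well, > 1000000 nM in this assay, so no number is known for it. The steps among the three, a step that the two limits leave unreadable from compound 1 to compound 2, a step that the two limits leave unreadable from compound 1 to compound 3 and a step that the two limits leave unreadable from compound 2 to compound 3, cannot be sized because every value sits at the limit of > 1000000 nM in this assay, at which 3 of the 3 values shown sit.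

Compound 4 `NC(C(=O)O)c1cnn(O)c1C(c1ccccc1)c1ccccc1` is the next member; relative to compound 3 the change is phenyl in place of hydrogen on a saturated chain carbon bound to two aromatic carbons. The measured steps that bear on this change are the three above, all unreadable, so they set no direction and no size for this assay; the one thing they show is that exchanging ethyl, cyclopropyl and phenyl at this carbon never brought a value inside the measurable window.

On that basis compound 4 is expected to give 1000000 nM in this assay, most likely again reported as a limit, with a range of 300000 nM to 3000000 nM. The step expected from compound 3 to compound 4 is a number no higher from compound 3 to compound 4 (the limit leaves the size open), estimated as nothing beyond the scatter.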

Compound 4, half-maximal effective concentration: > 1000000 nM
Compound 4: no number, only a limit; the forecaster's own chance of this, stated with the estimate: 85%; the middle value lies on the limit itself.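

Within the data shown here, compound 3 and compound 4 both give only a limit in this assay, and the step between them cannot be read, so no new step emerges. All values shown in this assay stand at one limit: the limit of > 1000000 nM in this assay, at which 4 of the 4 values shown sit.

The compounds shown leave open whether any change at this saturated chain carbon would bring a measurable value in this assay.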